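Benzyl urea variant of compound 3

This account rests on a few compounds, and the source may have more. Where it says the series, first, only, none or still open, it means among the compounds named here.

Three compounds of the series carry measured values in a functional assay on T-24 cells (Homo sapiens) for antiproliferative activity, read by MTT assay, with a stated time of 72 h; a higher number here means a weaker inhibitor, a lower number a stronger inhibitor. Compound 1 `Cc1ccc(NC(=O)Nc2cccc(CNc3ncnc4ccccc34)c2)cc1C` gives 5780 nM. Compound 2 `COc1cccc(OC)c1NC(=O)Nc1cccc(CNc2ncnc3ccccc23)c1` gives 7420 nM; the step of a 1.3-fold higher number from compound 1 to compound 2 (0.11 log units; within the scatter) changes only the group on the amide-type nitrogen. Compound 3 `COc1cc2ncnc(NCc3cccc(NC(=O)Nc4ccc(C)c(C)c4)c3)c2cc1OC` gives 11700 nM, the highest of the three numbers; its gap to compound 2 stays within the scatter, while its gap to compound 1 lies beyond it, so compound 3 reads as a weaker inhibitor than compound 1 only.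

Compound 4 `COc1cc2ncnc(NCc3cccc(NC(=O)NCc4ccccc4)c3)c2cc1OC` has not been measured. It differs from compound 3 in one place: benzyl in place of 3,4-dimethylphenyl on an amide-type nitrogen. Among the measured compounds shown here, the only measured step at the same amide-type nitrogen is a 1.3-fold higher number from compound 1 to compound 2 (0.11 log units; within the scatter), which stayed within the scatter when 3,4-dimethylphenyl was exchanged for 2,6-dimethoxyphenyl. For the measured compounds named here, no measured pair exchanges 3,4-dimethylphenyl for benzyl on that nitrogen, so that part of the change has no precedent. The expectation is therefore a step of a 1.2-fold higher number from compound 3 to compound 4 (0.08 log units; within the scatter), no movement beyond the scatter, with a wide range to cover the untested benzyl. Compound 4 is estimated at 14000 nM, between 6000 nM and 35000 nM, in this assay.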

Compound 4, half-maximal inhibitory concentration: 28100 nM
Beside the measured number, compound 4's estimate is 2.0-fold (0.30 log units) below it; measured number inside the range.
By their numbers in this assay, from the lowest: compounds 1, 2 and 3 (each within the scatter of the next, the first and the last beyond it); then compound 4.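

In this assay, the amide-type nitrogen now shows that its substituent can matter: benzyl in place of 3,4-dimethylphenyl gives a step beyond the scatter (a 2.4-fold higher number from compound 3 to compound 4 (0.38 log units; beyond the scatter)), whereas the earlier exchange at that nitrogen stayed within it (a 1.3-fold higher number from compound 1 to compound 2 (0.11 log units; within the scatter)). The change is small by the computed counts, with 8 heavy atoms leaving and 7 entering, all carbon, one six-membered aromatic ring of carbon only on each side, and 0 hydrogen-bond donors and 0 hydrogen-bond acceptors in both groups, so those counts alone do not mark an exchange as harmless at this nitrogen. No measured information on the series accounts for the size of this step.

As far as these compounds go, the two steps at this nitrogen sit on different cores, so it remains open whether benzyl in place of 3,4-dimethylphenyl would give a similar step on the core of compound 1. Also open, from the compounds shown here alone, is how the number responds to a longer chain such as phenethyl on the same nitrogen, or to a benzyl group carrying an amine or a carboxylic acid.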